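Nitro in Place of Bromo: What to Expect for Compound 4

The source may report more compounds than this note shows. Statements on the series, on what has been measured and on what is new or still open speak of the compounds shown alone.

Measured compounds:
Compound 1, `O=C1C(=O)N(CCCn2cc(COc3cc(=O)oc4ccccc34)nn2)c2ccc(F)cc21`, gives 69%.
Compound 2, `O=C1C(=O)N(CCCn2cc(COc3cc(=O)oc4ccccc34)nn2)c2ccc(Br)cc21`, gives 61%.
Compound 3, `O=C1C(=O)N(CCCCCn2cc(COc3cc(=O)oc4ccccc34)nn2)c2ccc([N+](=O)[O-])cc21`, gives 23%.

In a functional assay on COLO 205 cells (Homo sapiens) for inhibition, read by sulforhodamine B assay, with a stated time of 48 h, tested at 50 uM (on this read-out lower numbers stand for less inhibition of growth and higher numbers for more inhibition of growth at the one concentration tested), compound 2 stands second highest of the three numbers; compound 1 lies nearest, and the step of a number 8 percentage points lower from compound 1 to compound 2 (within the scatter) is within the scatter, while compound 3 lies furthest, well below compound 2 and beyond the scatter. Compound 4, `O=C1C(=O)N(CCCn2cc(COc3cc(=O)oc4ccccc34)nn2)c2ccc([N+](=O)[O-])cc21`, has not yet been measured. It differs from compound 2 in one place: nitro in place of bromo on an aromatic carbon. Among the compounds with values here, no measured step shows this exact exchange. Within the data shown here, the only measured step, that of bromo for fluoro, changed little. Among the measured compounds shown here, compound 3 is the only compound carrying a nitro group, and its value is low, though it also carries a longer chain, so its number is the only hint. Compound 4 is therefore expected to give 42%, within a range from 20% to 65%, leaning downward because compound 3 gives 23%. This estimate means an expected step of a number 19 percentage points lower from compound 2 to compound 4 (beyond the scatter).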

Compound 4, percent growth inhibition at one concentration: 52%
The estimate for compound 4 lay 10 percentage points below the measured number; low and high end bracket the measured number.
By their numbers in this assay, from the lowest: compound 3; then compounds 4, 2 and 1 (each within the scatter of the next, the first and the last beyond it).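

Within the data shown here, the exchange of bromo for nitro at this position gives a number 9 percentage points lower from compound 2 to compound 4 (within the scatter) in this assay and the exchange of fluoro for nitro gives a number 17 percentage points lower from compound 1 to compound 4 (beyond the scatter) and is the first step at this position to pass the scatter. With the same nitro group, compound 3 on the longer chain gives 23% and compound 4 on the shorter chain gives 52% so the low number of compound 3 does not follow from the nitro group alone. Nothing available here accounts for these differences.

The compounds shown leave open how an amine or a carboxylic acid at this position would read. They also leave open how the longer chain would read with fluoro or bromo in place of nitro.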